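The compounds below may be only part of what the source reports. "The series", "measured", "known", "first", "only" and "open" are said of these compounds alone.

In a functional assay on HepG2 cells (Homo sapiens) for inhibition, read by MTT assay (a lower number here means a stronger inhibitor of growth, a higher number a weaker inhibitor of growth), the measured compounds so far are:
compound 1 `COc1cc2oc(-c3cccc(NC(=O)c4ccc([N+](=O)[O-])cc4)c3)cc(=O)c2c(OC)c1OC` with 18800 nM
compound 2 `COc1cc2oc(-c3cccc(NC(=O)c4ccc(C)cc4)c3)cc(=O)c2c(OC)c1OC` with 9750 nM

Compound 2 stands within the scatter of compound 1, so neither of the two leads the series. Compound 3 `COc1cccc(C(=O)Nc2cccc(-c3cc(=O)c4c(OC)c(OC)c(OC)cc4o3)c2)c1` departs from compound 2 by 3-methoxyphenyl in place of 4-methylphenyl on a carbonyl carbon in the form of 3-methoxyphenyl in place of 4-methylphenyl on a carbonyl carbon. Among the measured compounds shown here, one measured step bears on this change, a 1.9-fold lower number from compound 1 to compound 2 (0.29 log units; within the scatter), with methyl in place of nitro on an aromatic carbon. For the measured compounds named here, that single step is thin support, and no measured compound carries 3-methoxyphenyl. Nothing in the data points to a larger move in this assay for this change, so no step beyond the scatter is expected. The estimated outcome is a 1.2-fold higher number from compound 2 to compound 3 (0.09 log units; within the scatter) as an expectation only. Compound 3 is expected at 12000 nM by this estimate, with an estimated range from 5500 nM to 26000 nM for the coming measurement.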

Compound 3, concentration for 50% growth inhibition: 7060 nM
The estimate for compound 3 lay 1.7-fold (0.23 log units) above the measured number; the measured number falls inside the stated range.
By their numbers in this assay, from the lowest: compounds 3, 2 and 1 (each within the scatter of the next, the first and the last beyond it).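

In this assay, 3-methoxyphenyl in place of 4-methylphenyl on a carbonyl carbon gives a 1.4-fold lower number from compound 2 to compound 3 (0.14 log units; within the scatter), so these two groups cannot be told apart at this position. Against 4-nitrophenyl, the same 3-methoxyphenyl group gives a 2.7-fold lower number from compound 1 to compound 3 (0.43 log units; beyond the scatter), the first step in the series to pass the scatter, although it remains modest and separates only the two end compounds. No evidence on hand accounts for either step.

As far as these compounds go, it remains open whether an aminophenyl group, a carboxylic acid or a longer alkyl chain on the carbonyl carbon would move the number further than these aryl groups do. From the compounds shown here alone, it is also open whether the step from compound 1 follows the loss of nitro or the arrival of methoxy, since that change swaps both at once.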